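Chloro for Methoxy on a Shared Core: Cytotoxicity Limits

The source may hold more compounds than are shown below. What is called first, only, known or untested is meant among the compounds shown, and "the series" means these compounds.

Compound 1, `CCOC(=O)c1c(-c2cccc(-c3ccccc3)c2)[nH]c2cc(OC)c(OC)cc2c1=O`: > 21500 nM
Compound 2, `CCOC(=O)c1c(-c2cccc(OC)c2)[nH]c2cc(OC)c(OC)cc2c1=O`: > 21500 nM
Compound 3, `CCOC(=O)c1c(-c2cccc(OC)c2)[nH]c2cc(Cl)c(OC)cc2c1=O`: > 21500 nM

In an ADME assay on HepG2 cells (Homo sapiens) for cytotoxicity, read by luminescence, with a stated time of 72 h (on this read-out higher numbers stand for an effect only at larger amounts of compound and lower numbers for an effect already at smaller amounts), compound 2 gives only a limit, > 21500 nM, and not a number. Compound 1 likewise gives only a limit in this assay. Compound 3 likewise gives only a limit in this assay. All three values sit at the limit of > 21500 nM in this assay, at which 3 of the 3 values shown sit, so compound 2 stands level with its two neighbours on what the numbers show, and nothing separates them.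

Compound 4, `CCOC(=O)c1c(-c2cccc(OC)c2)[nH]c2cc(OC)c(Cl)cc2c1=O`, differs from compound 2 by chloro in place of methoxy on an aromatic carbon. Among the measured compounds shown here, two measured steps bear on this change: a step that the two limits leave unreadable from compound 1 to compound 2 and a step that the two limits leave unreadable from compound 2 to compound 3. The second of these is the same kind of exchange, chloro in place of methoxy on an aromatic carbon of the fused system, and it too left both ends at the limit.

For the measured compounds named here, from this, no step in this assay beyond the scatter is expected for compound 4, in either direction, and it is expected to be reported as a limit again. The estimate for compound 4 is 30000 nM, with a range from 15000 nM to 80000 nM. The expected step is a step that the limit leaves unreadable from compound 2 to compound 4.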

Compound 4, half-maximal effective concentration: > 21500 nM
Compound 4 gave a limit, no number (the forecaster's own chance of this, stated with the estimate: 80%); the middle value lies beyond the limit too.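

In this assay, among the compounds shown here, compound 4, like compound 2, gives only a limit and not a number, so no step between the two can be read. The compounds shown leave open at what concentration any of them would affect these cells, and whether chloro and methoxy differ here.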